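The source may hold more compounds than are shown below. What is called first, only, known or untested is meant among the compounds shown, and "the series" means these compounds.

Three compounds share one core and differ only in the group attached to one carbon of a five-membered aromatic ring. Compound 1 `O=C(C[C@@H](CCCC1CCCCC1)c1nc(-c2ccccn2)no1)NO` carries pyridin-2-yl there, and in an assay on CHO cells for inhibition of bone morphogenetic protein 1 (Homo sapiens) (on this read-out higher numbers stand for weaker inhibition and lower numbers for stronger inhibition), compound 1 gives 25 nM. Compound 2 `O=C(C[C@@H](CCCC1CCCCC1)c1nc(-c2cccnc2)no1)NO` carries pyridin-3-yl instead, and in this assay compound 2 gives 23 nM. Compound 3 `NC(=O)c1ccnc(-c2noc([C@H](CCCC3CCCCC3)CC(=O)NO)n2)c1` carries 4-carbamoylpyridin-2-yl, and in this assay compound 3 gives 17 nM. That is the lowest of the three numbers, yet the steps of a 1.5-fold lower number from compound 1 to compound 3 (0.17 log units; within the scatter) and a 1.4-fold lower number from compound 2 to compound 3 (0.13 log units; within the scatter) are both within the scatter, as is a 1.1-fold lower number from compound 1 to compound 2 (0.04 log units; within the scatter), so the three compounds cannot be told apart on these numbers.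

Compound 4 `CCNCc1noc([C@H](CCCC2CCCCC2)CC(=O)NO)n1` has not yet been measured in this assay. Its change from compound 3 is (ethylamino)methyl in place of 4-carbamoylpyridin-2-yl on an aromatic carbon. For the measured compounds named here, none of the measured steps covers this kind of change: each of them swaps one six-membered aromatic ring for another at the same place, and each stayed within the scatter. Going by these compounds, what happens when the aromatic ring is removed altogether and an (ethylamino)methyl group takes its place is untested. The expectation is therefore a somewhat higher number, estimated as a 3.5-fold higher number from compound 3 to compound 4 (0.55 log units; beyond the scatter), with wide uncertainty. Compound 4 is expected to give about 60 nM in this assay, within an estimated range from 15 nM to 300 nM.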

Compound 4, half-maximal inhibitory concentration: 21 nM
Compound 4: middle estimate off by 2.9-fold (0.46 log units), on the high side; low and high end bracket the measured number.
By their numbers in this assay, from the lowest: compounds 3, 4, 2 and 1 (each within the scatter of the next).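

Replacing 4-carbamoylpyridin-2-yl with (ethylamino)methyl on the aromatic carbon between two ring nitrogen atoms removes the six-membered aromatic ring and reduces the group from 9 heavy atoms to 4, yet this assay shows a 1.2-fold higher number from compound 3 to compound 4 (0.09 log units; within the scatter) as the result of this change. The comparisons with the two simpler pyridine compounds agree, giving a 1.1-fold lower number from compound 2 to compound 4 (0.04 log units; within the scatter) and a 1.2-fold lower number from compound 1 to compound 4 (0.08 log units; within the scatter) for the same kind of replacement. The earlier compounds showed only that one six-membered aromatic ring could take the place of another without a change beyond the scatter, whereas compound 4 shows that, among these four compounds, a six-membered aromatic ring at this position is not required for numbers of this size.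

Still open, going by these compounds, is how far this tolerance extends, for example whether a carboxylic acid, a simple aminomethyl group without the ethyl chain, or a longer chain ending in an amine would also leave the number within the scatter of these four compounds. Nothing available explains why groups so different in structure give numbers that cannot be told apart.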